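Notes on a carboxymethyl acid series: compound 2 to compound 3

A few compounds are considered here, and "the series" means these few. Any claim that something is new, unique, unknown or untested is made for them only; others in the source may bear on it.

Measured so far:
compound 1 `O=C(O)Cc1sc(NC(=O)c2ccccc2)nc1-c1ccc(Cl)cc1`: 520 nM
compound 2 `O=C(O)Cc1sc(C(c2ccc(F)cc2)c2ccc(F)cc2)nc1-c1ccccc1`: 16 nM

In an in vitro assay on HEK385-7 cells for displacement of a labelled ligand from prostaglandin D2 receptor 2 (Homo sapiens) (a lower number here means a stronger inhibitor, a higher number a weaker inhibitor), compound 2 gives 16 nM, the lowest of the two numbers recorded. Compound 1 gives 520 nM in this assay, a gap beyond the scatter; the two compounds differ in more than one place, so their values are noted without reading a single change into them.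

Compound 3 `O=C(O)Cc1sc(C(c2ccc(F)cc2)c2ccc(F)cc2)nc1-c1cc(F)cc(F)c1` is the next member, and it differs from compound 2 by 3,5-difluorophenyl in place of phenyl on an aromatic carbon. Within the data shown here, no measured pair in this set differs in one place only, so there is no measured step to lean on. The expectation is a step of no more than the scatter from compound 2, with no direction beyond it, as expressed by a 1.3-fold lower number from compound 2 to compound 3 (0.12 log units; within the scatter). Compound 3 is accordingly estimated at 12 nM in this assay, within a range of 4 nM to 40 nM.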

Compound 3, half-maximal inhibitory concentration: 35 nM
Estimate against measurement, compound 3: 2.9-fold (0.46 log units) below, within the range that was stated.
By their numbers in this assay, from the lowest: compound 2; then compound 3; then compound 1.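

In this assay, the only one-place change shown is at the aromatic carbon next to the ring nitrogen, and it gives a 2.2-fold higher number from compound 2 to compound 3 (0.34 log units; beyond the scatter) with 3,5-difluorophenyl in place of phenyl. This position therefore responds to substitution on the phenyl ring: the two added fluorines carry a modest cost in this assay, and the step lies beyond the scatter. No measurement here bears on why the number rises.

A single step gives no trend at this position, and it cannot show whether one fluorine alone would produce a similar step. It also leaves open how a methoxy group, an amine or a larger halogen such as chlorine on this phenyl ring would compare, with the rest of compound 2 kept unchanged.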